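This account rests on a few compounds, and the source may have more. Where it says the series, first, only, none or still open, it means among the compounds named here.

Working notes on the series. Compound 1 `C=CCN1C(=O)N(Cc2ccccc2)S(=O)(=O)n2cccc21` in an ADME assay on MT4 cells (Homo sapiens) for cytotoxicity, read by MTT assay, with a stated time of 5 days (a higher number here means that more compound is tolerated, a lower number that less compound is tolerated), gives only a limit, > 802000 nM. That limit is the limit of > 802000 nM in this assay, at which 1 of the 3 values shown sits. Compound 2 `O=C1N(Cc2ccccc2Cl)c2cscc2S(=O)(=O)N1Cc1ccccc1` in this assay likewise gives only a limit, > 119000 nM. That limit is the limit of > 119000 nM in this assay, at which 1 of the 3 values shown sits. Compound 3 `N#CCN1C(=O)N(Cc2ccccc2)S(=O)(=O)c2cscc21` gives a number in this assay, 503000 nM, so all three values sit far up the concentration scale. Within the data shown here, the one step between measured compounds that differ in a single place, a step that the limit leaves unreadable from compound 2 to compound 3, cannot be sized, so no measured step offers a readable magnitude for comparison.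

Compound 4 `Cc1ccc(CN2C(=O)N(Cc3ccccc3)S(=O)(=O)n3cccc32)cc1` is not yet measured. It differs from compound 1 by 4-methylphenyl in place of vinyl on a saturated chain carbon bound to an amide-type nitrogen in a ring. Among the measured compounds shown here, no measured pair shows this change, and the step from compound 1 to compound 4 is thus estimated from the spread of the three known values alone, none of which falls into a range of marked cytotoxicity. For compound 4 the expected step of an at least 2.6-fold lower number from compound 1 to compound 4 (0.42 log units; beyond the scatter) is small, within the scatter or close to it, with a real chance that this assay again returns only a limit rather than a number. Compound 4 is accordingly expected to give 300000 nM, within a range from 80000 nM to 900000 nM.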

Compound 4, half-maximal cytotoxic concentration: 241000 nM
Beside the measured number, compound 4's estimate is 1.2-fold (0.10 log units) above it; low and high end bracket the measured number.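

In this assay, 4-methylphenyl in place of vinyl on a saturated chain carbon bound to an amide-type nitrogen in a ring gives the only readable step among the compounds shown, an at least 3.3-fold lower number from compound 1 to compound 4 (0.52 log units; beyond the scatter). The change from allyl to 4-methylbenzyl thus brings in a six-membered aromatic ring of carbon only, and less compound is tolerated, although compound 4 at 241000 nM still sits far up the concentration scale. The size of this step is only a minimum, since the value for compound 1 is a limit: the limit of > 802000 nM in this assay, at which 1 of the 4 values shown sits.

As far as these compounds go, whether the lower number goes with the aromatic ring itself or with the methyl on it stays open, as does the outcome with a longer chain or a carboxylic acid at this place. The other step between compounds shown cannot be read, so it also stays open whether this change would carry over to the core of compound 3.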